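The source may report more compounds than this note shows. Statements on the series, on what has been measured and on what is new or still open speak of the compounds shown alone.

Measured compounds:
compound 1 `ClCc1ccc(Cn2cnc3c(Cl)ncnc32)cc1`: 1620 nM
compound 2 `ClCc1ccc(Cn2cnc3nc(Cl)nc(Cl)c32)cc1`: 1620 nM
compound 3 `ClCc1ccc(Cn2cnc3c(Cl)nc(Cl)nc32)cc1`: 12600 nM

All three numbers come from a functional assay on MDA-MB-435 cells (Homo sapiens) for cytotoxicity, read by sulforhodamine B assay, with a stated time of 48 h; a higher number here means a weaker inhibitor of growth, a lower number a stronger inhibitor of growth. Compound 1 and compound 2 stand level at the digits given, within the scatter; compound 3 sits apart from both. Compound 2 and compound 3 are built from the same atoms joined differently, and the difference between the two cores is not broken down here. Compound 3 and compound 1 differ in one place: hydrogen in place of chloro on an aromatic carbon. That change brought a 7.8-fold lower number from compound 3 to compound 1 (0.89 log units; beyond the scatter), a modest step, but one beyond the scatter.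

Compound 4, `ClCc1ccc(Cn2cnc3ncnc(Cl)c32)cc1`, has not yet been measured. It is related to compound 2 by the same change, (hydrogen in place of chloro on an aromatic carbon). The place descriptions of the two changes match word for word, so this counts as the same change and not merely the same kind. The expectation rests on a single precedent, a 7.8-fold lower number from compound 3 to compound 1 (0.89 log units; beyond the scatter), together with the fact that compound 2 starts level with compound 1. If the change carries over, compound 4 is expected to move by a 4.6-fold lower number from compound 2 to compound 4 (0.67 log units; beyond the scatter) in this assay. The estimate for compound 4 in this assay is 350 nM, with an expected range from 130 nM to 1300 nM. The range is kept wide: one step on one pair is the whole basis, and a repeat of that step is not guaranteed.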

Compound 4, concentration for 50% growth inhibition: 5880 nM
Beside the measured number, compound 4's estimate is 17-fold (1.23 log units) below it; the measured number lies above the stated range.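

In this assay, hydrogen in place of chloro on an aromatic carbon gives a 3.6-fold higher number from compound 2 to compound 4 (0.56 log units; beyond the scatter), so the step seen on the other core does not carry over in size or in direction: the same change on two cores in this assay, a 7.8-fold lower number (0.89 log units; beyond the scatter) from compound 3 to compound 1 and a 3.6-fold higher number (0.56 log units; beyond the scatter) from compound 2 to compound 4, 28-fold (1.45 log units) apart, beyond the scatter of two such steps

For this series, the two pairs show that the result of this change depends on the core that carries it, and that one pair is not a safe guide to the next; the same replacement lowers the number on one core and raises it on the other. Within the data shown here, they do not show what in the cores sets the two steps apart, and with only two pairs, read in a single cell line at a single stated time, no rule can be drawn about which cores will follow which direction.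

The compounds shown leave open whether an amine or a methoxy group on the carbon between two ring nitrogen atoms would follow either step, since only chloro and hydrogen appear at that place. They also leave open how the two cores respond when the chloromethyl group shared by all four compounds gives way to a hydroxymethyl group or a longer chain.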